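Amide variation on the shared thiazole-carboxamide core

The source may report more compounds than this note shows. Statements on the series, on what has been measured and on what is new or still open speak of the compounds shown alone.

Measured so far:
compound 1 `CN(Cc1ccccc1)C(=O)c1sc(-c2ccc(S(C)(=O)=O)c([N+](=O)[O-])c2)nc1C(F)(F)F`: 3300 nM
compound 2 `Cc1nc(-c2ccc(S(C)(=O)=O)c([N+](=O)[O-])c2)sc1C(=O)N1CCC(C)CC1`: 7400 nM

In a functional assay for antagonist activity at thyroid hormone receptor beta (Homo sapiens), read by fluorescence polarization, with a stated time of 3 h (on this read-out higher numbers stand for weaker inhibition and lower numbers for stronger inhibition), compound 1 gives 3300 nM, the lower of the two measured values. Compound 2 gives 7400 nM in this assay, a gap from compound 1 that lies beyond the usual scatter. Compound 3 `CC1(C)CC2CC(C)(CN2C(=O)c2sc(-c3ccc(S(C)(=O)=O)c([N+](=O)[O-])c3)nc2C(F)(F)F)C1` is not yet measured. It differs from compound 1 by a group of 11 heavy atoms (10 carbon, 1 nitrogen; one five-membered non-aromatic ring with 1 hetero atom, one six-membered non-aromatic ring of carbon only) in place of a group of 9 heavy atoms (8 carbon, 1 nitrogen; one six-membered aromatic ring of carbon only), on a carbonyl carbon. Among the measured compounds shown here, no single-place step between measured compounds is available to calibrate this kind of change, so in this assay no shift beyond the scatter is expected in either direction. Compound 3 is estimated at 3000 nM, within 900 nM to 10000 nM, which means an expected step of a 1.1-fold lower number from compound 1 to compound 3 (0.04 log units; within the scatter).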

Compound 3, half-maximal inhibitory concentration: 2100 nM
Estimate against measurement, compound 3: 1.4-fold (0.15 log units) above; measured number inside the range.
By their numbers in this assay, from the lowest: compounds 3 and 1 (each within the scatter of the next); then compound 2.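

In this assay, the group on the carbonyl carbon tolerates a large change: exchanging benzyl(methyl)amino for the group with one five-membered and one six-membered non-aromatic ring gives a 1.6-fold lower number from compound 1 to compound 3 (0.20 log units; within the scatter). In this pair, the six-membered aromatic ring of the leaving group is therefore not needed to keep the number within the scatter. No measured evidence bears on the cause of this result.

Compound 2 differs from compound 1 in more than one place, so it does not separate the contribution of the amide group. As far as these compounds go, how a carboxylic acid or a primary amine carried on the amide group would read remains open.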